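Replacing One Sulfonamide Group on Compound 2

This account rests on a few compounds, and the source may have more. Where it says the series, first, only, none or still open, it means among the compounds named here.

In a physicochemical assay for lipophilicity, at pH 7.4 (a lower number here means a more polar compound, a higher number a more lipophilic compound), compound 1 `Cc1ccc(N(C2CCC2)S(=O)(=O)c2ccc3c(c2)C(O)CC(C2CCOCC2)O3)c(C)c1` reads 3.77 and compound 3 `CCc1ccc(N(CC(C)C)S(=O)(=O)c2ccc3c(c2)C(C)CC(C2CCOCC2)O3)cc1` reads 5.71 on the scale. Compound 2 `CCS(=O)(=O)c1ccc(CN(CC(C)C)S(=O)(=O)c2ccc3c(c2)C(O)CC(C2CCOCC2)O3)nc1` reads 1.42 and stands lowest of the three, with both others beyond the usual scatter above it.

The next molecule, compound 4 `CC(C)CN(c1ccc(F)cc1)S(=O)(=O)c1ccc2c(c1)C(O)CC(C1CCOCC1)O2`, has not yet been measured. It differs from compound 2 in one place, where 4-fluorophenyl stands in place of (5-(ethylsulfonyl)pyridin-2-yl)methyl on a sulfonamide nitrogen. The counted difference 4-fluorophenyl in place of (5-(ethylsulfonyl)pyridin-2-yl)methyl on a sulfonamide nitrogen sums up this swap.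

Within the data shown here, no measured pair differs in just one place, so no direct step can serve as a guide. The nearest reference is compound 1 at 3.77 in this assay since it also carries a carbon-only aromatic ring on its sulfonamide nitrogen. A large upward change beyond the scatter is therefore expected, estimated as a number 2.18 log units higher from compound 2 to compound 4 (beyond the scatter) in this assay overall. For compound 4 the expected reading is 3.6 within an estimated range of 3 to 4.2 on the same scale.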

Compound 4, distribution coefficient: 3.39
Estimate against measurement, compound 4: 0.21 log units above, within the range that was stated.
By their numbers in this assay, from the lowest: compound 2; then compound 4; then compound 1; then compound 3.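

At the sulfonamide nitrogen, 4-fluorophenyl in place of (5-(ethylsulfonyl)pyridin-2-yl)methyl gives a number 1.97 log units higher from compound 2 to compound 4 (beyond the scatter) in this assay. Among these compounds, this is the first pair that differs in one place, so it shows that this substituent alone can shift the reading by a large step while the rest of the molecule stays fixed. The group that leaves counts 12 heavy atoms and 3 hydrogen-bond acceptors against 7 and 0 for the group that enters, but nothing measured here accounts for the shift.

From the compounds shown here alone, how the step divides among the parts of the departing group remains open, and a plain benzyl group or a pyridine ring without the ethylsulfonyl on the same nitrogen would bear on that. A single pair also leaves open whether a step of this size would recur on a different set of the remaining groups, or with an amine or a carboxylic acid at this position.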